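The compounds below may be only part of what the source reports. "The series", "measured", "known", "first", "only" and "open" are said of these compounds alone.

The measured compounds in an ADME assay on MRC5 cells (Homo sapiens), read by MTT assay, with a stated time of 72 h; a lower number here means a stronger inhibitor, a higher number a weaker inhibitor:
Compound 1 `COc1ncnc2c1c(-c1ccoc1)cn2[C@@H]1O[C@H](CO)[C@@H](O)[C@H]1O` gives 29400 nM.
Compound 2 `COc1ncnc2c1c(-c1cccs1)cn2[C@@H]1O[C@H](CO)[C@@H](O)[C@H]1O` gives 43200 nM.
Compound 3 `COc1nc(N)nc2c1c(-c1cccs1)cn2[C@@H]1O[C@H](CO)[C@@H](O)[C@H]1O` yields only a limit of the assay, > 100000 nM.

Among the two numbers shown, compound 2 carries the higher one, yet the step of a 1.5-fold higher number from compound 1 to compound 2 (0.17 log units; within the scatter) is within the scatter, so compound 1 and compound 2 cannot be told apart on these data. The third value is a limit, (the limit of > 100000 nM in this assay, at which 1 of the 3 values shown sits).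

Compound 4 `CNc1ncnc2c1c(-c1cccs1)cn2[C@@H]1O[C@H](CO)[C@@H](O)[C@H]1O` has not been measured in this assay. It differs from compound 2 by methylamino in place of methoxy on an aromatic carbon.

Within the data shown here, no measured step exchanges methoxy for methylamino. Among the measured compounds shown here, the only step touching the same six-membered ring is an at least 2.3-fold higher number from compound 2 to compound 3 (0.36 log units; beyond the scatter), in which an entering amino group, bringing a hydrogen-bond donor, pushes the number to the limit (the limit of > 100000 nM in this assay, at which 1 of the 3 values shown sits). The change to compound 4 likewise brings a hydrogen-bond donor, but in place of an acceptor-bearing methoxy rather than in addition to it, so the account expects at most a modest upward step in this assay, and possibly none beyond the scatter.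

Compound 4 is therefore estimated at 55000 nM, with a range from 20000 nM to 130000 nM. The expected step is a 1.3-fold higher number from compound 2 to compound 4 (0.10 log units; within the scatter).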

Compound 4, half-maximal inhibitory concentration: > 100000 nM
Compound 4 was reported as a limit (the forecaster's own chance of this, stated with the estimate: 30%); middle value at least 1.8-fold (0.25 log units) away from the limit.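

In this assay, exchanging methoxy for methylamino on the aromatic carbon gives an at least 2.3-fold higher number from compound 2 to compound 4 (0.36 log units; beyond the scatter). Among these compounds, this shows that the group on this carbon matters in its own right, whereas the earlier compounds showed a rise only when an amino group entered on a different carbon of the same six-membered ring, with the methoxy kept in place. Here the number of heavy atoms stays the same and no group is added, yet compound 4, like compound 3, reaches a limit of the assay, so the two cannot be ordered against each other: the limit of > 100000 nM in this assay, at which 2 of the 4 values shown sit.

The compounds shown cannot tell whether the step follows from the hydrogen-bond donor that enters or from the nitrogen in place of oxygen, and a dimethylamino group on this carbon, which keeps the nitrogen and carries no such hydrogen, would separate the two. Going by these compounds, how far compound 4 lies past its limit also stays unknown, as does whether a smaller group such as a plain amine or a longer chain such as ethylamino would behave in the same way on this carbon.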